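Replacing a methoxy with a cyano on the biaryl

The source may hold more compounds than are shown below. What is called first, only, known or untested is meant among the compounds shown, and "the series" means these compounds.

The two measured compounds share a core in which a biaryl is linked through a benzyl ether to a phenyl bearing a sulfonylacetic acid. Compound 1 `COc1cc(C)c(-c2cccc(COc3ccc(S(=O)(=O)CC(=O)O)cc3)c2)c(C)c1` carries a 4-methoxy-2,6-dimethylphenyl on this core, and in a functional assay on CHO cells for agonist activity at Free fatty acid receptor 1 (Homo sapiens), read by FLIPR and calcium flux (a higher number here means that more compound is needed for the effect, a lower number that less compound is needed), compound 1 gives 57.5 nM. Within the data shown here, compound 2 `COc1ccccc1-c1cccc(COc2ccc(S(=O)(=O)CC(=O)O)cc2)c1` carries a 2-methoxyphenyl instead, and in this assay compound 2 gives 195 nM, which is the highest of the two numbers; the only measured step, a 3.4-fold higher number from compound 1 to compound 2 (0.53 log units; beyond the scatter), concerns the loss of two methyl groups and the shift of the methoxy, not the nature of the group itself.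

Compound 3 `N#Cc1ccccc1-c1cccc(COc2ccc(S(=O)(=O)CC(=O)O)cc2)c1` differs from compound 2 by a single exchange: cyano in place of methoxy on an aromatic carbon. Among the measured compounds shown here, no measured step bears on a cyano in place of a methoxy, so the expectation rests on compound 2 alone. The step from compound 2 to compound 3 in this assay is expected to be a 1.0-fold higher number from compound 2 to compound 3 (0.01 log units; within the scatter), that is, no change beyond the scatter in either direction. For compound 3 in this assay the estimate is 200 nM, within a range of 70 nM to 600 nM.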

Compound 3, half-maximal effective concentration in the Free fatty acid receptor 1 assay: 457 nM
Compound 3: the middle estimate sits 2.3-fold (0.36 log units) below what was measured; measured number inside the range.
By their numbers in the Free fatty acid receptor 1 assay, from the lowest: compound 1; then compound 2; then compound 3.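

In the Free fatty acid receptor 1 assay the exchange at this position, on an aromatic carbon ortho to a large group, is not neutral, with a 2.3-fold higher number from compound 2 to compound 3 (0.37 log units; beyond the scatter), although methoxy and cyano each have 2 heavy atoms, 1 hydrogen-bond acceptor and no net charge. The earlier step changed the methyl groups and the place of the methoxy together, whereas this one shows that the identity of this single group alone moves the number beyond the scatter. The wider comparison, a 7.9-fold higher number from compound 1 to compound 3 (0.90 log units; beyond the scatter), leaves the 2-cyanophenyl compound with the highest number of the three, and nothing supplied here explains why the cyano compound needs more compound for the effect.

The compounds shown leave open whether the rise belongs to the cyano group in particular or would also follow from a different group here, such as an amine, a chlorine or a hydroxyl, and whether the methyl groups of compound 1 would lower the number with a cyano in place too. Among these compounds, in a physicochemical assay for lipophilicity, using the shake flask method, in phosphate buffer, measured as octanol-water partition, with a stated time of 24 h, at pH 7.4, tested at 100 uM (a higher number here means a more lipophilic compound, a lower number a more polar compound), compound 2 gives "not determined" (no result reported) and compound 3 gives "not determined" (no result reported), so no step from compound 2 to compound 3 can be read, and the two compounds cannot be compared there.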